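This account rests on a few compounds, and the source may have more. Where it says the series, first, only, none or still open, it means among the compounds named here.

Compound 1 `COc1cc(-c2cc(/C=C/C(=O)c3ccc(Cl)c(Cl)c3)[nH]n2)cc(OC)c1OC` gives 9% in a functional assay on CCRF-CEM cells (Homo sapiens) for cytotoxicity, read by sulforhodamine B assay, with a stated time of 48 h, tested at 10 uM; on this read-out higher numbers stand for a weaker effect at the one concentration tested and lower numbers for a stronger effect. For the measured compounds named here, compound 2 `COc1ccc(C(=O)/C=C/c2cc(-c3cc(OC)c(OC)c(OC)c3)n[nH]2)cc1OC` gives -26% in that assay, the lowest of the two numbers, and the change a number 35 percentage points lower from compound 1 to compound 2 (beyond the scatter) is the only step measured so far. Compound 3 `COc1ccc(C(=O)/C=C/c2cc(-c3cc(OC)c(OC)c(OC)c3)n[nH]2)cc1` differs from compound 2 by hydrogen in place of methoxy on an aromatic carbon. Going by the values given here, no measured step removes a methoxy group, and the one step known altered a different pair of groups, so it offers no direct guide. The number for compound 3 is therefore expected to be near that of compound 2, a step of a number 11 percentage points higher from compound 2 to compound 3 (beyond the scatter) within the scatter, with an estimate of -15% ranging from -50% to 20%.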

Compound 3, a percentage reported as activity, at one concentration (the size of the read-out at that concentration, not a potency): -19%
The estimate for compound 3 lay 4 percentage points above the measured number; measured number inside the range.
By their numbers in this assay, from the lowest: compounds 2 and 3 (each within the scatter of the next); then compound 1.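

Going from 3,4-dimethoxyphenyl to 4-methoxyphenyl gives, in this assay, a number 7 percentage points higher from compound 2 to compound 3 (within the scatter), so this methoxy group can be replaced by hydrogen without a change beyond the usual scatter. Compared with 3,4-dichlorophenyl, the 4-methoxyphenyl group still gives a number 28 percentage points lower from compound 1 to compound 3 (beyond the scatter), so the second methoxy group is not needed for that difference to appear. No measurement here explains either result. The compounds shown leave open whether a hydroxyl group or an amine on this aromatic carbon would match hydrogen and methoxy, and what removing the remaining methoxy group would do.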